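A few compounds are considered here, and "the series" means these few. Any claim that something is new, unique, unknown or untested is made for them only; others in the source may bear on it.

Four compounds share the same kind of build: a propylamide on a ring, joined through a second amide to a bicyclic aromatic core carrying a methoxybenzyl group. Compound 1, `CCCNC(=O)[C@@H]1C[C@H]2CCC[C@@H](C1)[C@@H]2NC(=O)c1cc2scnc2n1Cc1ccc(OC)cc1`, and compound 3, `CCCNC(=O)[C@@H]1C[C@H]2CCC[C@@H](C1)[C@@H]2NC(=O)c1cc2sc(-c3ccccc3)nc2n1Cc1ccc(OC)cc1`, have a bridged bicyclic amine as the linking ring; compound 2, `CCCNC(=O)C1CCN(C(=O)c2cc3scnc3n2Cc2ccc(OC)cc2)CC1`, and compound 4, `CCCNC(=O)C1CCN(C(=O)c2cc3sc(-c4ccccc4)nc3n2Cc2ccc(OC)cc2)CC1`, have a piperidine instead. The difference between the two cores is not broken down here.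

All were or will be tested in an ADME assay on HEK-293T cells (Homo sapiens) for cytotoxicity, read by luminescence and CellTiter-Glo, with a stated time of 24 h; on this read-out higher numbers stand for lower toxicity in this test and lower numbers for higher toxicity in this test. Compound 1 reaches only a limit of this assay, > 25000 nM. Compound 3 likewise reaches only a limit, > 100000 nM. Compound 2 gives a number, 19100 nM.

From compound 1 to compound 3 the change is phenyl in place of hydrogen on an aromatic carbon. The step this made is a step that the two limits leave unreadable from compound 1 to compound 3; it cannot be sized because the limit of > 25000 nM in this assay, at which 1 of the 3 values shown sits, is where compound 1 sits and the limit of > 100000 nM in this assay, at which 1 of the 3 values shown sits, is where compound 3 sits.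

From compound 2 to compound 4 the change is phenyl in place of hydrogen on an aromatic carbon, the same change at the same place. The step for this pair is expected to be a 1.6-fold higher number from compound 2 to compound 4 (0.20 log units; within the scatter). This rests on compound 2 giving 19100 nM and on a step that the two limits leave unreadable from compound 1 to compound 3 leaving the size of the same change open, so little shift is assumed. Compound 4 is estimated at 30000 nM, between 10000 nM and 100000 nM.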

Compound 4, half-maximal cytotoxic concentration: 22900 nM
The estimate for compound 4 lay 1.3-fold (0.12 log units) above the measured number; the range from low to high includes it.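

In this assay, phenyl in place of hydrogen on an aromatic carbon gives a 1.2-fold higher number from compound 2 to compound 4 (0.08 log units; within the scatter), so in the pair built on a piperidine the two numbers cannot be told apart. The same swap in the pair built on the bridged bicyclic amine cannot be sized, as compound 1 and compound 3 each give only a limit of this assay, not a number. On these data alone, this means the series offers one readable pair, which shows how the swap reads on the core of compound 2 but does not show that it would read the same on the core of compound 1, so carrying the result from one core to another remains untested.

The compounds shown have only hydrogen or phenyl on this aromatic carbon, so it remains open how this read-out would respond to an amine or a carboxylic acid there. Also open, as far as these compounds go, is what would happen if a longer chain took the place of the propyl of the propylamide, or if an amine took the place of the methoxy of the methoxybenzyl group.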